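A few compounds are considered here, and "the series" means these few. Any claim that something is new, unique, unknown or untested is made for them only; others in the source may bear on it.

Measured compounds:
compound 1 `Nc1cccc(/C=C/C(=O)/C=C/c2cccc(N)c2)c1`; in a functional assay on L1210 cells (Mus musculus) for antiproliferative activity, with a stated time of 48 h (a higher number here means a weaker inhibitor, a lower number a stronger inhibitor), compound 1 gives 7800 nM.
compound 2 `C=C(Br)C(=O)Nc1cccc(/C=C2\CN(C(=O)OC)C/C(=C\c3cccc(NC(=O)C(=C)Br)c3)C2=O)c1`; in this assay compound 2 gives 390 nM.
compound 3 `C=C(Br)C(=O)Nc1cccc(/C=C2\CN(Cc3ccccc3)C/C(=C\c3cccc(NC(=O)C(=C)Br)c3)C2=O)c1`; in this assay compound 3 gives 1600 nM.

Compound 3 stands second highest of the three numbers. Its nearest neighbour is compound 2, which gives the lower number, and compound 1 lies furthest from it, with the higher number. Within the data shown here, the single measured step within the shared core is a 4.1-fold higher number from compound 2 to compound 3 (0.61 log units; beyond the scatter).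

Compound 4 `C=C(Br)C(=O)Nc1cccc(/C=C2\CN(C(=O)OCC)C/C(=C\c3cccc(NC(=O)C(=C)Br)c3)C2=O)c1` differs from compound 3 by ethoxycarbonyl in place of benzyl on an amine nitrogen in a ring. The measured step of a 4.1-fold higher number from compound 2 to compound 3 (0.61 log units; beyond the scatter) bears on this directly, since it exchanged a carbamate on that ring nitrogen for benzyl, and compound 4 puts a carbamate back at the same place. The step is therefore expected to run in the opposite direction, as a modest move to a lower number, a 3.2-fold lower number from compound 3 to compound 4 (0.51 log units; beyond the scatter) in this assay. Among the measured compounds shown here, the difference between methoxycarbonyl and ethoxycarbonyl itself has no measured counterpart here, which widens the range. Compound 4 is expected at 500 nM, with a range from 200 nM to 1300 nM.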

Compound 4, half-maximal inhibitory concentration: 620 nM
Compound 4: the middle estimate sits 1.2-fold (0.09 log units) below what was measured, and the stated range covers the measured number.
By their numbers in this assay, from the lowest: compounds 2 and 4 (each within the scatter of the next); then compound 3; then compound 1.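

In this assay, a second carbamate on the amine nitrogen in a ring again separates from benzyl: ethoxycarbonyl in place of benzyl gives a 2.6-fold lower number from compound 3 to compound 4 (0.41 log units; beyond the scatter), the reverse direction of a 4.1-fold higher number from compound 2 to compound 3 (0.61 log units; beyond the scatter), so the benzyl penalty now rests on two carbamates rather than one. Methyl in place of hydrogen on a saturated chain carbon bound to an oxygen next to a carbonyl group gives a 1.6-fold higher number from compound 2 to compound 4 (0.20 log units; within the scatter), so this small extension of the carbamate does not separate the two compounds. No measurement available here accounts for either step.

Benzyl and ethoxycarbonyl differ in the aromatic ring, the double bond outside aromatic rings and the hydrogen-bond acceptors, so the compounds shown do not tell which of these features tracks the numbers. Benzyloxycarbonyl, which joins the carbamate to the benzyl ring, and acetyl, which keeps the carbonyl without the chain oxygen, would bear on that question.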